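The source may hold more compounds than are shown below. What is called first, only, known or untested is meant among the compounds shown, and "the series" means these compounds.

Measured compounds:
compound 1 `COc1ccc(/C=C/C(=O)O)cc1OC(=O)c1nc(C)c(C)nc1C`: 128%
compound 2 `Cc1nc(C)c(C(=O)Oc2cccc(/C=C/C(=O)O)c2)nc1C`: 64.3%
compound 3 `CCOC(=O)/C=C/c1ccc(OC(=O)c2nc(C)c(C)nc2C)c(OC)c1`: 53.3%

Within the data shown here, in a functional assay on EA.hy 926 cells (Homo sapiens) for cytotoxicity, read by MTT assay, with stated times of 24 h and 12 h, tested at 25 uM (on this read-out higher numbers stand for a stronger effect at the one concentration tested and lower numbers for a weaker effect), the one counted step is a number 63.7 percentage points lower from compound 1 to compound 2 (beyond the scatter), where (hydrogen in place of methoxy on an aromatic carbon). Compound 4 `CCOC(=O)/C=C/c1ccc(OC(=O)c2nc(C)c(C)nc2C)cc1` has not yet been measured; it arises from compound 3 by hydrogen in place of methoxy on an aromatic carbon. The difference between the core of compound 1 and the core of compound 3 is not broken down here. The two changes are the same kind of change, but their surroundings differ: the first place is para to a 2-carboxyethenyl group, the second meta to a 2-(ethoxycarbonyl)ethenyl group. Compound 3 stands lowest of the three measured compounds, so a fall as large as the earlier one cannot be expected from it. For compound 4 the expected step is a number 21.3 percentage points lower from compound 3 to compound 4 (beyond the scatter), a smaller fall resting on a number 63.7 percentage points lower from compound 1 to compound 2 (beyond the scatter). Compound 4 is thus expected to give about 32%, between 10% and 55%.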

Compound 4, a percentage reported as activity, at one concentration (the size of the read-out at that concentration, not a potency): 58.8%
The estimate for compound 4 lay 26.8 percentage points below the measured number, and the stated range ends below it.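

Hydrogen in place of methoxy on an aromatic carbon gives a number 5.5 percentage points higher from compound 3 to compound 4 (within the scatter) in this assay and so, on this core, no change that can be told from the scatter. The size of this step therefore cannot be carried over from one core to the other in this series: the same change on two cores in this assay, a number 63.7 percentage points lower (beyond the scatter) from compound 1 to compound 2 and a number 5.5 percentage points higher (within the scatter) from compound 3 to compound 4, 69.2 percentage points apart, beyond the scatter of two such steps. This rests on one pair per core, and it does not show which part of the difference between the two cores separates the steps, nor how the change would behave on any third core.

The compounds shown leave open whether an amine or a longer alkoxy chain in place of the methoxy would follow either step. They also leave open how an amide in place of the ester linking the two halves would read out.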